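Cytotoxicity notes: cyclohexyl to pyridinylmethyl on the core

A few compounds are considered here, and "the series" means these few. Any claim that something is new, unique, unknown or untested is made for them only; others in the source may bear on it.

The series is followed in an ADME assay on BaF3 cells (Mus musculus) for cytotoxicity; on this read-out higher numbers stand for an effect only at larger amounts of compound and lower numbers for an effect already at smaller amounts. Compound 1 `COC(=O)c1cc2c(Nc3ccc(OC(F)(F)F)cc3)ncnc2s1` gives in this assay only a limit of the assay and not a number, > 10000 nM. Compound 2 `Cc1ccc(NC(=O)c2cccc(C(F)(F)F)c2)cc1C(=O)c1cc2c(Nc3ccc(OC(F)(F)F)cc3)ncnc2s1` gives in this assay a number, 8900 nM. Compound 3 `FC(F)(F)Oc1ccc(Nc2ncnc3nn(C4CCCCC4)cc23)cc1` again returns in this assay only a limit, > 10000 nM. Compound 3 therefore stands at the limit of > 10000 nM in this assay, at which 2 of the 3 values shown sit, and without a number it cannot be placed against compound 2 in this assay beyond saying that its effect was not reached within the tested range.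

Compound 4 `FC(F)(F)Oc1ccc(Nc2ncnc3nn(Cc4cccnc4)cc23)cc1` is not yet measured in this assay. It differs from compound 3 by (pyridin-3-yl)methyl in place of cyclohexyl on an aromatic nitrogen. Going by the values given here, no step between two measured compounds in this assay exists in the data, so nothing here shows how such an exchange moves the read-out. Among the compounds with values here, compound 3 sits at the limit, and with no step of this kind on record the change from compound 3 to compound 4 is expected to be none beyond the scatter, a step that the limit leaves unreadable from compound 3 to compound 4. Compound 4 is accordingly estimated in this assay at 15000 nM, with a range from 7000 nM to 40000 nM, and it is likely that the assay again reports only a limit.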

Compound 4, half-maximal effective concentration: > 10000 nM
Compound 4: only a limit was reported; the forecaster's own chance of this, stated with the estimate: 75%; the middle value is on the limit's open side.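

In this assay, compound 3 and compound 4 both return only a limit, so no step can be read for (pyridin-3-yl)methyl in place of cyclohexyl, and the series mostly sits at one point: the limit of > 10000 nM in this assay, at which 3 of the 4 values shown sit.

The compounds shown leave open whether this exchange on the aromatic nitrogen moves the read-out at all.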